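Swapping chloro for methyl on a weak oxindole thiosemicarbazone

This account rests on a few compounds, and the source may have more. Where it says the series, first, only, none or still open, it means among the compounds named here.

Three compounds built around a halogenated oxindole linked through a thiosemicarbazone to an aryl ring have been tested in a functional assay on CCRF-CEM cells (Homo sapiens), with a stated time of 72 h; on this read-out higher numbers stand for weaker inhibition and lower numbers for stronger inhibition. Compound 1 `O=C1Nc2cc(Cl)c(F)cc2/C1=N/NC(=S)Nc1ccc(Cl)cc1` carries a chloro group on the outer aryl ring, and in this assay compound 1 gives 48000 nM. Compound 2 `Cc1ccc(NC(=S)N/N=C2\C(=O)Nc3cc(Cl)c(F)cc32)cc1` differs from it in one place: methyl in place of chloro on an aromatic carbon. That step, a 2.8-fold higher number from compound 1 to compound 2 (0.44 log units; beyond the scatter), makes compound 2 the weaker of the pair, with compound 2 giving 132000 nM in this assay.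

Compound 3 `Cc1ccc(NC(=S)N/N=C2\C(=O)N(Cc3ccc(Cl)cc3)c3ccc(Br)cc32)cc1` rests on a different core, and the difference between the two cores is not broken down here. In this assay compound 3 gives only a limit, >= 500000 nM, not a number; this is the limit of >= 500000 nM in this assay, at which 1 of the 3 values shown sits.

Compound 4 `Cc1ccc(CN2C(=O)/C(=N\NC(=S)Nc3ccc(C)cc3)c3cc(Br)ccc32)cc1` stands to compound 3 as compound 2 stands to compound 1: methyl in place of chloro on an aromatic carbon. The place is the same, although cut one bond further out the change reads 4-chlorobenzyl to 4-methylbenzyl rather than (4-chlorophenyl)amino to (4-methylphenyl)amino, so it is the same change in a different part of the molecule.

For the measured compounds named here, the only measured example of this change weakened inhibition modestly, and compound 3 already sits at the limit with >= 500000 nM. Compound 4 is therefore expected to show a step that the limit leaves unreadable from compound 3 to compound 4, most likely again reported only as a limit. The estimate for compound 4 in this assay is 700000 nM, spanning 250000 nM to 2500000 nM.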

Compound 4, half-maximal inhibitory concentration: >= 500000 nM
Compound 4 ended at the assay's limit; the forecaster's own chance of this, stated with the estimate: 85%; the middle value lies beyond the limit too.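

Compound 3 and compound 4 both end at a limit rather than a number, so no step between them can be read: the limit of >= 500000 nM in this assay, at which 2 of the 4 values shown sit.

Still open, on these data alone, is whether changing 4-chlorobenzyl to 4-methylbenzyl shifts inhibition in this assay in the same direction as the change of chloro to methyl between compound 1 and compound 2, and by how much.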